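The source may hold more compounds than are shown below. What is called first, only, known or untested is meant among the compounds shown, and "the series" means these compounds.

The measured compounds and their values:

- compound 1, `COC(=O)C1=C(C)NC(C)=C(C(=O)OC)C1c1ccc(-c2cc(=O)cc(-c3ccccc3)o2)cc1`: 4710 nM
- compound 2, `CCOC(=O)C1=C(C)NC(C)=C(C(=O)OCC)C1c1ccc(-c2cc(=O)cc(-c3ccccc3)o2)cc1`: 12200 nM
- compound 3, `COC(=O)C1=C(C)NC(C)=C(C(=O)OC)C1c1ccc(-c2cc(=O)cc(C)o2)cc1`: 17800 nM

In an assay on isolated protein (strain albino) for inhibition of Voltage-dependent L-type calcium channel subunit alpha-1C (Cavia porcellus) (a lower number here means a stronger inhibitor, a higher number a weaker inhibitor), compound 2 gives the second highest of the three numbers. Its nearest neighbour is compound 3, whose value lies within the scatter of that of compound 2, while compound 1 sits a clear distance lower. Compound 4, `CCOC(=O)C1=C(C)NC(C)=C(C(=O)OCC)C1c1ccc(-c2cc(=O)cc(C)o2)cc1`, has not yet been measured. It differs from compound 2 by methyl in place of phenyl on an aromatic carbon, the same change that separates compound 1 from compound 3. That step is the only one in this set that bears on the question, and it was a 3.8-fold higher number from compound 1 to compound 3 (0.58 log units; beyond the scatter). Carrying the same change over to the ethyl ester pair, compound 4 is expected to give a number higher than that of compound 2 by about the same margin, so that the step from compound 2 to compound 4 is estimated as a 3.3-fold higher number from compound 2 to compound 4 (0.52 log units; beyond the scatter). On that basis compound 4 is expected to show 40000 nM in this assay, with a plausible range from 15000 nM to 110000 nM.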

Compound 4, half-maximal inhibitory concentration: 2140 nM
For compound 4 the middle estimate is 19-fold (1.27 log units) above the measured one; the measured number lies below the stated range.
By their numbers in this assay, from the lowest: compound 4; then compound 1; then compounds 2 and 3 (each within the scatter of the next).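

In this assay, methyl in place of phenyl on this aromatic carbon, next to the ring oxygen, gives a 5.7-fold lower number from compound 2 to compound 4 (0.76 log units; beyond the scatter) on the ethyl esters. This change therefore has no single direction at this position, since it lowers the number in this pair but raises it in the methyl ester pair. The two pairs differ only in their ester groups, so the outcome at this position depends on the ester the core carries, and the gap between the two steps exceeds the scatter: the same change on two cores in this assay, a 3.8-fold higher number (0.58 log units; beyond the scatter) from compound 1 to compound 3 and a 5.7-fold lower number (0.76 log units; beyond the scatter) from compound 2 to compound 4, 22-fold (1.33 log units) apart, beyond the scatter of two such steps.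

The compounds shown carry only phenyl or methyl at this position and only methyl or ethyl esters, so it stays open whether the reversal would hold for a propyl ester or for an amine at this position. They also leave open why the two steps run in opposite directions.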